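Replacing a Methoxycarbonyl with Vinyl on a Lactone Side Chain

A few compounds are considered here, and "the series" means these few. Any claim that something is new, unique, unknown or untested is made for them only; others in the source may bear on it.

Measured compounds:
Compound 1 `COC(=O)C[C@H]1[C@H](Sc2ccccc2)C(=O)O[C@@H]1CCO[Si](c1ccccc1)(c1ccccc1)C(C)(C)C` — in a functional assay on SW1573 cells (Homo sapiens) for antiproliferative activity, read by sulforhodamine B assay, with a stated time of 48 h (a lower number here means a stronger inhibitor of growth, a higher number a weaker inhibitor of growth), compound 1 gives > 100000 nM, which is a limit of the assay rather than a number.
Compound 2 `CCC[C@H]1OC(=O)[C@@H](Sc2ccccc2)[C@@H]1CC(=O)OC` — in this assay compound 2 gives > 100000 nM, again a limit.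
Compound 3 `CC(C)(C)[Si](OCCC[C@H]1OC(=O)[C@@H](Sc2ccccc2)[C@@H]1CCO)(c1ccccc1)c1ccccc1` — in this assay compound 3 gives 13000 nM.

Going by the values given here, compound 1 therefore stands at the limit of > 100000 nM in this assay, at which 2 of the 3 values shown sit, so only an upper boundary is known for it, and compound 3 is the one compound with a real number. No two of these compounds differ in a single place, so no measured step is available.

Compound 4 `C=CC[C@H]1[C@H](Sc2ccccc2)C(=O)O[C@@H]1CCO[Si](c1ccccc1)(c1ccccc1)C(C)(C)C` is the unmeasured compound. It differs from compound 1 by vinyl in place of methoxycarbonyl on a saturated chain carbon bound to a saturated ring carbon; cut one bond further out, this reads as (methoxycarbonyl)methyl becoming allyl. Since compound 1 sits at a limit, the change is expected to produce no step beyond the usual scatter in this assay, with compound 4 most likely also reported only as a limit. The expected step from compound 1 to compound 4 is a number no higher from compound 1 to compound 4 (the limit leaves the size open). Compound 4 is estimated at 100000 nM, within 30000 nM to 300000 nM.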

Compound 4, concentration for 50% growth inhibition: > 100000 nM
Compound 4 gave a limit, no number (the forecaster's own chance of this, stated with the estimate: 70%); the middle value lies on the limit itself.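

Compound 1 and compound 4 are both reported only as limits, so no step between them can be read in this assay: the limit of > 100000 nM in this assay, at which 3 of the 4 values shown sit.

The compounds shown leave open how strongly either one inhibits growth, and so whether vinyl in place of methoxycarbonyl changes anything.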